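The source may report more compounds than this note shows. Statements on the series, on what has been measured and on what is new or still open speak of the compounds shown alone.

Among the measured compounds shown here, compound 1 `CC(=O)c1ccc(NC(=O)CCCCCCNC(=O)C(O)(O)C(F)(F)F)cc1` carries the highest number of the three measured members in a functional assay on HCT-116 cells (Homo sapiens) for inhibition, read by colorimetric assay, with a stated time of 3 days (on this read-out lower numbers stand for stronger inhibition and higher numbers for weaker inhibition), where compound 1 gives 12100 nM. Compound 2 `O=C(CCCCCCNC(=O)C(O)(O)C(F)(F)F)Nc1ccc(S(F)(F)(F)(F)F)cc1` gives 9110 nM, and the step of a 1.3-fold lower number from compound 1 to compound 2 (0.12 log units; within the scatter). Compound 3 `O=C(CCCCCCNC(=O)C(O)(O)C(F)(F)F)Nc1ccc(-c2ccccc2)cc1` gives 4730 nM; the step of a 2.6-fold lower number from compound 1 to compound 3 (0.41 log units; beyond the scatter), while a 1.9-fold lower number from compound 2 to compound 3 (0.28 log units; within the scatter).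

Compound 4 `COc1cccc(NC(=O)CCCCCCNC(=O)C(O)(O)C(F)(F)F)c1` differs from compound 1 in one place: 3-methoxyphenyl in place of 4-acetylphenyl on an amide-type nitrogen. None of the three measured steps matches this change. Each of them swaps a single group on an aromatic carbon of the anilide while keeping the rest of the aryl group; here the whole 4-acetylphenyl gives way to 3-methoxyphenyl. What the measured steps do show is that exchanging the group on the aryl ring moves the read-out only a little, with a 1.3-fold lower number from compound 1 to compound 2 (0.12 log units; within the scatter) and a 2.6-fold lower number from compound 1 to compound 3 (0.41 log units; beyond the scatter) as the two steps from compound 1. On that basis the step from compound 1 to compound 4 in this assay is expected to be small, most likely within the scatter, with no firm direction; the expected step is a 1.2-fold lower number from compound 1 to compound 4 (0.08 log units; within the scatter). The number for compound 4 in this assay is therefore estimated at 10000 nM, within a range of 4000 nM to 25000 nM.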

Compound 4, half-maximal inhibitory concentration: 6110 nM
Compound 4: the middle estimate sits 1.6-fold (0.21 log units) above what was measured; low and high end bracket the measured number.
By their numbers in this assay, from the lowest: compounds 3, 4, 2 and 1 (each within the scatter of the next, the first and the last beyond it).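

In this assay, 3-methoxyphenyl in place of 4-acetylphenyl on the amide-type nitrogen gives a 2.0-fold lower number from compound 1 to compound 4 (0.30 log units; within the scatter). Unlike the earlier steps, which swap one group on an aromatic carbon, this change replaces the whole aryl group, altering both the group carried by the ring and the ring location given in its name, and the step still lies within the scatter. No measurement bears on the reason for this result.

Because the group and its ring location change together, the compounds shown cannot tell whether the methoxy or acetyl group counts for more than its place on the ring. Also open, going by these compounds, is how an amine or a carboxylic acid on the aryl ring, or a longer chain in place of the one in the shared core, would read in this assay.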